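The compounds below may be only part of what the source reports. "The series", "measured", "known", "first", "only" and "open" are said of these compounds alone.

Working notes on the series. Compound 1 `Cc1ccc(CSc2n[nH]c(-n3[se]c4ccccc4c3=O)n2)cc1` gives > 50000 nM in a functional assay on SMMC-7721 cells (Homo sapiens) for antiproliferative activity, read by CCK-8 assay, with a stated time of 48 h (on this read-out higher numbers stand for weaker inhibition and lower numbers for stronger inhibition), a limit of the assay rather than a number. Compound 2 `O=c1c2ccccc2[se]n1-c1nc(SCc2ccc(Cl)cc2)n[nH]1` gives 33900 nM in this assay. Compound 3 `CC(C)Sc1n[nH]c(-n2[se]c3ccccc3c2=O)n1` gives 6010 nM in this assay, the lowest of the two numbers shown, the nearest number being a step away, a 5.6-fold lower number from compound 2 to compound 3 (0.75 log units; beyond the scatter). The other step runs the same way, an at least 8.3-fold lower number from compound 1 to compound 3 (0.92 log units; beyond the scatter), resting on (the limit of > 50000 nM in this assay, at which 1 of the 3 values shown sits). Compound 4 `Cc1ccccc1CSc1n[nH]c(-n2[se]c3ccccc3c2=O)n1` differs from compound 3 by 2-methylbenzyl in place of isopropyl on a sulfur. Both measured steps put isopropyl in place of a benzyl group and lowered the number; the change to compound 4 runs the other way, so a higher number of about that size is expected in this assay. Compound 4 is therefore estimated near 30000 nM, with a range from 10000 nM to 60000 nM. The expected step is a 5.0-fold higher number from compound 3 to compound 4 (0.70 log units; beyond the scatter).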

Compound 4, half-maximal inhibitory concentration: 36200 nM
Estimate against measurement, compound 4: 1.2-fold (0.08 log units) below, within the range that was stated.
By their numbers in this assay, from the lowest: compound 3; then compounds 2 and 4 (each within the scatter of the next). At a limit, above all of these: compound 1.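

In this assay, a third benzyl-type group on this sulfur, 2-methylbenzyl, also sits well away from isopropyl (a 6.0-fold higher number from compound 3 to compound 4 (0.78 log units; beyond the scatter)), so all three benzyl-type compounds shown lie on the higher side of compound 3. Exchanging 4-chlorophenyl for 2-methylphenyl on the saturated chain carbon separates nothing (a 1.1-fold higher number from compound 2 to compound 4 (0.03 log units; within the scatter)). The value of compound 1 is a limit, so its step (an at least 1.3-fold lower number from compound 1 to compound 4 (0.14 log units; that floor lies within the scatter)) gives only a floor and does not order 2-methylphenyl and 4-methylphenyl: (the limit of > 50000 nM in this assay, at which 1 of the 4 values shown sits). On these data alone, whether an amine or a carboxylic acid at the end of a longer chain on this sulfur would bring the number down to that of compound 3 or beyond remains open.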